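Amide nitrogen substituent change in the bromo series

The compounds below may be only part of what the source reports. "The series", "measured", "known", "first", "only" and "open" are said of these compounds alone.

- Compound 1 `N[C@H]1CC[C@H](NC(=O)c2nc(Br)c3cccnc3c2NCc2ccc(F)cc2)CC1`: 7100 nM
- Compound 2 `COc1ccc(CNC(=O)c2nc(Br)c3cccnc3c2N[C@H]2CC[C@H](N)CC2)cc1`: 4000 nM
- Compound 3 `C[C@H](NC(=O)c1nc(Br)c2cccnc2c1N[C@H]1CC[C@H](N)CC1)c1ccc(F)cc1`: > 10000 nM, a limit and not a number

In a functional assay on HEY cells (Homo sapiens) for cytotoxicity, read by MTT assay, with a stated time of 72 h (a lower number here means a stronger inhibitor, a higher number a weaker inhibitor), compound 3 gives only a limit: the limit of > 10000 nM in this assay, at which 1 of the 3 values shown sits. Its position is therefore known from one side only.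

Compound 4 `N[C@H]1CC[C@H](Nc2c(C(=O)NC3CCCCC3)nc(Br)c3cccnc23)CC1` has cyclohexyl in place of 1-(4-fluorophenyl)ethyl on an amide-type nitrogen.

Within the data shown here, one measured step bears on this change, as it alters the same nitrogen: an at least 2.5-fold higher number from compound 2 to compound 3 (0.39 log units; beyond the scatter). That step shows that the group here can move the number in this assay beyond the scatter. Among the measured compounds shown here, no measured compound carries cyclohexyl, so the direction rests on a single comparison. Compound 3 is replaced by a group that has not been tested, and a return towards compound 2 at 4000 nM is expected. A second limit remains possible.

Similar in size to the measured step and towards a lower number, the estimated change is expected to be an at least 2.0-fold lower number from compound 3 to compound 4 (0.30 log units; that floor lies within the scatter).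

For compound 4 the estimated value is 5000 nM, with an expected range of 2000 nM to 12000 nM.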

Compound 4, half-maximal inhibitory concentration: 5200 nM
For compound 4 the middle estimate is 1.0-fold (0.02 log units) below the measured one, and the stated range covers the measured number.
By their numbers in this assay, from the lowest: compounds 2, 4 and 1 (each within the scatter of the next). At a limit, above all of these: compound 3.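

In this assay, the measured step of a 1.3-fold higher number from compound 2 to compound 4 (0.11 log units; within the scatter) shows that replacing 4-methoxybenzyl with cyclohexyl on the amide-type nitrogen leaves the number within the scatter, so an aromatic ring is not needed there for a value in this range. The step of an at least 1.9-fold lower number from compound 3 to compound 4 (0.28 log units; that floor lies within the scatter) gives only a floor that lies within the scatter, so the true size of this change cannot be read. Compound 3 remains a limit and not a number: the limit of > 10000 nM in this assay, at which 1 of the 4 values shown sits.

Going by these compounds, it remains open whether a smaller ring such as cyclopropyl or a plain methyl on this nitrogen would keep the number in this range. On these data alone, it is also open whether a hydroxyl or an amine on the cyclohexyl ring would move the number beyond the scatter.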